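The source may report more compounds than this note shows. Statements on the series, on what has been measured and on what is new or still open speak of the compounds shown alone.

In a functional assay on NSCLC cells (Homo sapiens) for cytotoxicity, read by sulforhodamine B assay, with a stated time of 48 h (a higher number here means a weaker inhibitor of growth, a lower number a stronger inhibitor of growth), compound 1 (`COc1cc2c(cc1C)NC(=O)/C2=C/c1c(OC)nc2sc(C)cn12`) gives 5250 nM while compound 2 (`COc1ccc2c(c1)/C(=C\c1c(OC)nc3sc(C)cn13)C(=O)N2`) gives 1490 nM as its value. Compound 3 (`COc1nc2sc(C)cn2c1/C=C1/C(=O)Nc2ccc(O)cc21`) gives 7540 nM as its value, which lies within the scatter of compound 1 and clearly higher than compound 2. Compound 4 (`COc1nc2sc(C)cn2c1/C=C1/C(=O)Nc2ccccc21`) carries hydrogen in place of hydroxy on an aromatic carbon. The closest guide is the change at that same carbon, where hydrogen replaced methyl on the oxygen, with a 5.1-fold higher number from compound 2 to compound 3 (0.70 log units; beyond the scatter) as its result. A looser guide, at another aromatic carbon, is a 3.5-fold lower number from compound 1 to compound 2 (0.55 log units; beyond the scatter) as measured. Neither step removes a hydroxy outright, so a modest fall is expected, with a 2.5-fold lower number from compound 3 to compound 4 (0.40 log units; beyond the scatter) as the estimate. For compound 4 the expected value is 3000 nM (range 1000 nM to 8000 nM).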

Compound 4, concentration for 50% growth inhibition: 5680 nM
Compound 4: the middle estimate sits 1.9-fold (0.28 log units) below what was measured; measured number inside the range.
By their numbers in this assay, from the lowest: compound 2; then compounds 1, 4 and 3 (each within the scatter of the next).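

In this assay, hydrogen and hydroxy at this aromatic carbon cannot be told apart (a 1.3-fold lower number from compound 3 to compound 4 (0.12 log units; within the scatter)). Methoxy is the one group of these three that stands apart (a 3.8-fold higher number from compound 2 to compound 4 (0.58 log units; beyond the scatter)), so among these compounds, the lower number goes with the whole methoxy group and not with an oxygen alone at this carbon. Nothing measured here explains why methoxy differs. Still open, as far as these compounds go, is whether a longer chain on the oxygen, such as ethoxy, or an amine at this carbon would give a number like that of compound 2.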